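Chlorophenyl positional change on the triazole aryl group

The compounds below may be only part of what the source reports. "The series", "measured", "known", "first", "only" and "open" are said of these compounds alone.

Measured so far: compound 1 `O=c1[nH]cc(S(=O)(=O)Nc2ccc(-c3cn(-c4cccc(F)c4)nn3)cc2)c(=O)[nH]1` and compound 2 `O=c1[nH]cc(S(=O)(=O)Nc2ccc(-c3cn(-c4ccccc4Cl)nn3)cc2)c(=O)[nH]1`.

In a functional assay on OVCAR-3 cells (Homo sapiens) for antiproliferative activity, read by MTT assay, with a stated time of 24 h (a higher number here means a weaker inhibitor, a lower number a stronger inhibitor), compound 1 gives > 20000 nM, which is a limit of the assay and not a number. In this assay compound 2 gives 4270 nM, the only number shown. Among the measured compounds shown here, the single measured step is an at least 4.6-fold lower number from compound 1 to compound 2 (0.67 log units; beyond the scatter), read against (the limit of > 20000 nM in this assay, at which 1 of the 2 values shown sits). Compound 3 `O=c1[nH]cc(S(=O)(=O)Nc2ccc(-c3cn(-c4ccc(Cl)cc4)nn3)cc2)c(=O)[nH]1` differs from compound 2 by 4-chlorophenyl in place of 2-chlorophenyl on an aromatic nitrogen. For the measured compounds named here, no measured step changes the position of chlorine, so no direction is supported. A step within the scatter is expected: a 1.1-fold higher number from compound 2 to compound 3 (0.02 log units; within the scatter). Compound 3 is estimated at 4500 nM, between 1500 nM and 15000 nM.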

Compound 3, half-maximal inhibitory concentration: 2160 nM
Compound 3: middle estimate off by 2.1-fold (0.32 log units), on the high side, and the stated range covers the measured number.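

In this assay, 4-chlorophenyl in place of 2-chlorophenyl on the aromatic nitrogen gives a 2.0-fold lower number from compound 2 to compound 3 (0.30 log units; within the scatter), so these two chlorine placements are not told apart. 4-chlorophenyl in place of 3-fluorophenyl gives an at least 9.2-fold lower number from compound 1 to compound 3 (0.96 log units; beyond the scatter), which makes a second chlorophenyl step beyond the scatter. That step is bounded on one side only: the limit of > 20000 nM in this assay, at which 1 of the 3 values shown sits.

The compounds shown leave open how 3-chlorophenyl compares, which would separate the change of halogen from the change of position. Going by these compounds, how an amine or a carboxylic acid on this phenyl ring would read also remains open.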